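Working notes: from cyclopentylmethoxy to 3-isopropylphenyl

This account rests on a few compounds, and the source may have more. Where it says the series, first, only, none or still open, it means among the compounds named here.

Compound 1 `CCCN(CCC)c1nc(C(F)(F)F)ccc1CNC(=O)Nc1cccc2c(=O)[nH]ccc12` gives 2.79 nM in an assay on CHO cells for agonist activity at transient receptor potential cation channel subfamily V member 1 (Homo sapiens); on this read-out lower numbers stand for an effect already at smaller amounts and higher numbers for an effect only at larger amounts of compound.
Compound 2 `CC(C)COc1nc(C(F)(F)F)ccc1CNC(=O)Nc1cccc2c(=O)[nH]ccc12` gives 78.7 nM in this assay.
Compound 3 `O=C(NCc1ccc(C(F)(F)F)nc1OCC1CCCC1)Nc1cccc2c(=O)[nH]ccc12` gives 15.5 nM in this assay.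

Compound 3 holds the second highest number of the three: a 5.6-fold higher number from compound 1 to compound 3 (0.74 log units; beyond the scatter) and a 5.1-fold lower number from compound 2 to compound 3 (0.71 log units; beyond the scatter). Compound 4 `CC(C)c1cccc(-c2nc(C(F)(F)F)ccc2CNC(=O)Nc2cccc3c(=O)[nH]ccc23)c1` differs from compound 3 by 3-isopropylphenyl in place of cyclopentylmethoxy on an aromatic carbon. Among the compounds with values here, none of the measured steps tries an aryl group at this carbon; the steps seen there, a 28-fold higher number from compound 1 to compound 2 (1.45 log units; beyond the scatter) and a 5.1-fold lower number from compound 2 to compound 3 (0.71 log units; beyond the scatter), only show that changes at this position move the number by modest to large amounts in either direction. The expected outcome for compound 4 is therefore a modest shift, a 1.3-fold higher number from compound 3 to compound 4 (0.11 log units; within the scatter), with wide uncertainty. Compound 4 is estimated at 20 nM, range 3 nM to 150 nM.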

Compound 4, half-maximal effective concentration: 3.07 nM
Estimate against measurement, compound 4: 6.5-fold (0.81 log units) above; the measured number falls inside the stated range.
By their numbers in this assay, from the lowest: compounds 1 and 4 (each within the scatter of the next); then compound 3; then compound 2.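

At the aromatic carbon next to the ring nitrogen, an aryl group is tolerated in this assay and compares well with both alkoxy groups, giving a 5.0-fold lower number from compound 3 to compound 4 (0.70 log units; beyond the scatter) against cyclopentylmethoxy and a 26-fold lower number from compound 2 to compound 4 (1.41 log units; beyond the scatter) against isobutoxy. Against dipropylamino it gives a 1.1-fold higher number from compound 1 to compound 4 (0.04 log units; within the scatter) and so is not separated from that group, which means neither an oxygen nor a nitrogen on this carbon is required in this small set. Nothing available bears on the cause of these steps.

On these data alone, it remains open whether the isopropyl group of compound 4 contributes, which an unsubstituted phenyl or a 4-isopropylphenyl at this carbon would address. A cyclic amine such as piperidine in place of dipropylamino is also untested in the compounds shown here.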